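Inverting one ring stereocentre in a growth inhibitor pair

The source may hold more compounds than are shown below. What is called first, only, known or untested is meant among the compounds shown, and "the series" means these compounds.

For the measured compounds named here, in a functional assay on DLD-1 cells (Homo sapiens) for inhibition, read by luminescence, with a stated time of 3 days (a lower number here means a stronger inhibitor of growth, a higher number a weaker inhibitor of growth), compound 1 `CC[C@@H]1CC[C@@H](C(=O)N2CCN(C)CC2)N1C(=O)C1=C(C(C)C)N2C(=N[C@@](C)(c3ccc(Cl)cc3)[C@H]2c2ccc(Cl)cc2)S1` gives 4000 nM and compound 2 `CC[C@@H]1CC[C@@H](C(=O)N2CCN(C)[C@H](C)C2)N1C(=O)C1=C(C(C)C)N2C(=N[C@@](C)(c3ccc(Cl)cc3)[C@H]2c2ccc(Cl)cc2)S1` gives 3600 nM as its reading, so compound 2 stands level with compound 1 on the only two numbers available. Going by the values given here, the single measured step between them is a 1.1-fold lower number from compound 1 to compound 2 (0.05 log units; within the scatter) for a methyl in place of hydrogen on a saturated ring carbon. Compound 3 `CC[C@@H]1CC[C@@H](C(=O)N2CCN(C)[C@@H](C)C2)N1C(=O)C1=C(C(C)C)N2C(=N[C@@](C)(c3ccc(Cl)cc3)[C@H]2c2ccc(Cl)cc2)S1` departs from compound 2 in configuration alone (the two compounds have the same atoms and bonds and differ only in configuration as drawn: 1 of 5 stereo elements differ; a stereocentre at a saturated ring carbon is drawn R in compound 2 and S in compound 3). Among the compounds with values here, no measured pair inverts a stereocentre, so the data offer no direct guide to this change. Within the data shown here, the only indirect guide is the step of a 1.1-fold lower number from compound 1 to compound 2 (0.05 log units; within the scatter) seen between the two measured compounds, and it says nothing specific about the other drawn configuration. On that limited basis, no step beyond the scatter is expected in this assay and neither direction is favoured. In this assay compound 3 is expected at 3500 nM (estimated range 1800 nM to 7000 nM). This estimate amounts to an expected change (a 1.0-fold lower number from compound 2 to compound 3 (0.01 log units; within the scatter)).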

Compound 3, concentration for 50% growth inhibition in the DLD-1 assay: 3900 nM
For compound 3 the middle estimate is 1.1-fold (0.05 log units) below the measured one, and the stated range covers the measured number.
By their numbers in the DLD-1 assay, from the lowest: compounds 2, 3 and 1 (each within the scatter of the next).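

In the DLD-1 assay, inverting the stereocentre at this saturated ring carbon from R to S gives a 1.1-fold higher number from compound 2 to compound 3 (0.03 log units; within the scatter), and the methyl in its S form gives a 1.0-fold lower number from compound 1 to compound 3 (0.01 log units; within the scatter), so neither drawn configuration of the methyl separates from the unmethylated compound 1. In a physicochemical assay for solubility, read by HPLC, in phosphate buffer, at pH 6.8 (a lower number here means a less soluble compound, a higher number a more soluble compound), the same inversion gives a 1.1-fold higher number from compound 2 to compound 3 (0.06 log units; within the scatter), and the two configurations stand level there too, with compound 2 at 14 ug/mL and compound 3 at 16 ug/mL. The comparison speaks to this one stereocentre alone, because of a single fact: the fact that compounds 2 and 3 differ only in the configuration as drawn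

Whether an ethyl or a hydroxymethyl group at this carbon, in either configuration, would move the number in the DLD-1 assay beyond the scatter remains open, since a methyl is the only group shown here in place of hydrogen. The compounds shown also leave open what the step from hydrogen to methyl does in the physicochemical assay, where only the two methylated compounds can be compared.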